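The source may report more compounds than this note shows. Statements on the series, on what has been measured and on what is new or still open speak of the compounds shown alone.

Within the data shown here, in an ADME assay on HEK-293T cells (Homo sapiens) for inhibition, read by CCK-8 assay, with a stated time of 48 h, tested at 20 uM (on this read-out higher numbers stand for more inhibition of growth at the one concentration tested and lower numbers for less inhibition of growth), compound 1 (`N#C/C(=C\c1ccccc1OS(=O)(=O)c1ccc([N+](=O)[O-])cc1)C(=O)Nc1nnc(-c2cccs2)s1`) gives 33% and compound 2 (`COc1ccc(Cc2nnc(NC(=O)/C(C#N)=C/c3ccccc3OS(=O)(=O)c3ccc([N+](=O)[O-])cc3)s2)cc1`) gives 17%, which makes compound 2 the lower of the two numbers so far. Compound 3 (`COc1ccc(Cc2nnc(NC(=O)/C(C#N)=C/c3ccccc3OS(=O)(=O)c3ccc(F)cc3)s2)cc1`) keeps the 4-methoxybenzyl group of compound 2 but carries fluoro in place of nitro on an aromatic carbon, para to a large group, turning (4-nitrophenyl)sulfonyl into (4-fluorophenyl)sulfonyl: fluoro in place of nitro on an aromatic carbon. Among the measured compounds shown here, the only measured step, a number 16 percentage points lower from compound 1 to compound 2 (beyond the scatter), is modest and replaces thiophen-2-yl with 4-methoxybenzyl, so it does not test this exchange. For the measured compounds named here, no measured step involves the nitro group, and the data give no direction for the change in this assay. The expected result is a number 1 percentage points higher from compound 2 to compound 3 (within the scatter), with no step beyond the scatter anticipated. For compound 3, the estimated value is 18%, within an expected range of 5% to 35%.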

Compound 3, percent growth inhibition at one concentration: 6%
Compound 3: the middle estimate sits 12 percentage points above what was measured, within the range that was stated.
By their numbers in this assay, from the lowest: compound 3; then compound 2; then compound 1.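

Among these compounds, this is the first measured change at the aromatic carbon para to a large group: in this assay, fluoro in place of nitro gives a number 11 percentage points lower from compound 2 to compound 3 (beyond the scatter), a step beyond the usual scatter. Among the compounds shown here, the earlier compounds showed only that the group at the other end of the molecule affects this read-out, whereas this step shows that (4-nitrophenyl)sulfonyl and (4-fluorophenyl)sulfonyl are also not interchangeable here. No measurement offered here accounts for this difference.

On these data alone, it remains open whether the exchange would move the number in the same direction with thiophen-2-yl in place of 4-methoxybenzyl, since only the 4-methoxybenzyl pair tests it. As far as these compounds go, it is also open where a methyl group, an amine or a carboxylic acid at this position would fall relative to nitro and fluoro.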